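This account rests on a few compounds, and the source may have more. Where it says the series, first, only, none or still open, it means among the compounds named here.

Compound 1 `CN1C[C@@H](C(=O)c2ccccn2)[C@H](c2ccccc2)C1`: in an assay for inhibition of sodium-dependent dopamine transporter (Rattus norvegicus) (on this read-out lower numbers stand for stronger inhibition and higher numbers for weaker inhibition), compound 1 gives 630 nM.
Compound 2 `O=C(c1ccccn1)[C@@H]1CN(c2ccccc2)C[C@H]1c1ccccc1`: compound 2 reaches only the assay limit, > 10000 nM.

For the measured compounds named here, compound 2 therefore stands at the limit and its true number is not known; the single measured step, an at least 15-fold higher number from compound 1 to compound 2 (1.20 log units; beyond the scatter), concerns the substituent on the ring nitrogen, and the limit of > 10000 nM in this assay, at which 1 of the 2 values shown sits, is where compound 2 sits. Compound 3 `O=C(c1cccs1)[C@@H]1CN(c2ccccc2)C[C@H]1c1ccccc1` differs from compound 2 by thiophen-2-yl in place of pyridin-2-yl on a carbonyl carbon. Going by the values given here, no measured step touches the group on the carbonyl carbon, so the size of this step cannot be read from the measured pair. Compound 3 is expected to remain near the limit, an estimated step that the limit leaves unreadable from compound 2 to compound 3, with an estimate of 15000 nM and a range from 3000 nM to 60000 nM.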

Compound 3, inhibition constant: > 10000 nM
Compound 3 ended at the assay's limit; the forecaster's own chance of this, stated with the estimate: 70%; the middle value is on the limit's open side.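

No step can be read between compound 2 and compound 3, as both sit at an assay limit: the limit of > 10000 nM in this assay, at which 2 of the 3 values shown sit.

Going by these compounds, whether thiophen-2-yl in place of pyridin-2-yl on a carbonyl carbon changes the result in this assay at all stays open.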